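The source may hold more compounds than are shown below. What is called first, only, known or untested is meant among the compounds shown, and "the series" means these compounds.

Measured so far in an ADME assay on microsomes from liver (Mus musculus, strain CD-1) for metabolic stability, read by LC-MS, tested at 2 uM; a lower number here means that the compound disappears faster, a higher number that the compound lasts longer:
- compound 1 `Cn1cc(CNS(=O)(=O)c2ccccc2Nc2cc(-c3ccc4ccn(C)c4c3)c3nccnc3c2)cn1`: 0.267 h
- compound 2 `Cn1ccc2ccc(-c3cc(Nc4ccccc4S(=O)(=O)NCC4CCOCC4)cc4nccnc34)cc21`: 0.3 h
- compound 3 `Cn1ccc2ccc(-c3cc(Nc4cnccc4C(=O)NC4CCNC(=O)C4)cc4nccnc34)cc21`: > 1 h (a limit)

Compound 3 stands at the limit of > 1 h in this assay, at which 1 of the 3 values shown sits, and that is a limit and not a number.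

Next in the series is compound 4 `CC(=O)N1CC(CNC(=O)c2ccncc2Nc2cc(-c3ccc4ccn(C)c4c3)c3nccnc3c2)C1`. The change is (1-acetylazetidin-3-yl)methyl in place of 2-oxopiperidin-4-yl on an amide-type nitrogen.

For the measured compounds named here, no measured step starts from compound 3, and no measured step makes this same exchange. The nearest evidence is a 1.1-fold higher number from compound 1 to compound 2 (0.05 log units; within the scatter), where oxan-4-yl takes the place of 1-methyl-1H-pyrazol-4-yl on a saturated chain carbon bound to a sulfonamide nitrogen. That exchange involves different groups at a different attachment, so it is only a loose guide. It offers no support for a large step, and the starting point is a limit, so the half-life of compound 4 may also land at the limit.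

In this assay a shift no larger than the scatter is expected, with a slight lean towards a lower number. The estimated step is an at least 1.1-fold lower number from compound 3 to compound 4 (0.04 log units; that floor lies within the scatter). The estimate for compound 4 is 0.9 h, with an expected range of 0.4 h to 1.8 h.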

Compound 4, half-life: > 1 h
Compound 4 gave a limit, no number; the forecaster's own chance of this, stated with the estimate: 45%; middle value at least 1.1-fold (0.04 log units) from the limit.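

In this assay, compound 3 and compound 4 both give a limit and not a number, so no step between them can be read: the limit of > 1 h in this assay, at which 2 of the 4 values shown sit.

The compounds shown leave open the actual half-life of compound 3 and compound 4, and whether (1-acetylazetidin-3-yl)methyl in place of 2-oxopiperidin-4-yl on an amide-type nitrogen shifts it.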